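Working notes: from compound 3 to compound 4

A few compounds are considered here, and "the series" means these few. Any claim that something is new, unique, unknown or untested is made for them only; others in the source may bear on it.

Among the measured compounds shown here, the series so far holds compound 1 `CCCCCCNC(=O)NS(=O)(=O)N1CCC(CNC(=O)c2cc(Cl)ccc2OC)CC1`, compound 2 `COc1ccc(Cl)cc1C(=O)NCCC1CCN(S(=O)(=O)NC(=O)NC[C@@H]2C[C@@H]3C=C[C@@H]2C3)CC1` and compound 3 `CCCNC(=O)NS(=O)(=O)N1CCC(CCNC(=O)c2cc(Cl)ccc2OC)CC1`. In a functional assay on the whole organism (blood) with Rattus norvegicus as the target, with stated times of 24 h and 1 h, at a dose of 5 mg/kg by the intraperitoneal route (a higher number here means a stronger effect of the compound at the dose given, a lower number a weaker effect), compound 1 gives 17%, compound 2 gives 37%, and compound 3 gives 11%. Compound 3 stands lowest of the three numbers; its gap to compound 1 is within the scatter, its gap to compound 2 is beyond it. For the measured compounds named here, the one step that bears on the next change is a number 26 percentage points lower from compound 2 to compound 3 (beyond the scatter), where a group of 2 heavy atoms (2 carbon; no ring) replaced a group of 7 heavy atoms (7 carbon; 2 five-membered non-aromatic rings of carbon only) on a saturated chain carbon bound to an amide-type nitrogen.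

Compound 4 `COc1ccc(Cl)cc1C(=O)NCCC1CCN(S(=O)(=O)NC(=O)NC[C@@H]2C[C@@H]3CC[C@@H]2O3)CC1` reverses that kind of change: a group of 7 heavy atoms (6 carbon, 1 oxygen; 2 five-membered non-aromatic rings with 1 hetero atom each) in place of a group of 2 heavy atoms (2 carbon; no ring), on a saturated chain carbon bound to an amide-type nitrogen. The entering group carries one oxygen where the group in compound 2 carried carbon only, so the earlier step is a guide rather than an exact match. In this assay a rise of roughly that size is expected, and the step expected is a number 21 percentage points higher from compound 3 to compound 4 (beyond the scatter). Compound 4 is estimated at 32%, with a range from 15% to 50%.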

Compound 4, a percentage reported as activity, at one dose (the size of the read-out at that dose, not a potency): 30%
For compound 4 the middle estimate is 2 percentage points above the measured one; low and high end bracket the measured number.
By their numbers in this assay, from the lowest: compounds 3 and 1 (each within the scatter of the next); then compounds 4 and 2 (each within the scatter of the next).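

At the saturated chain carbon bound to an amide-type nitrogen, a group with two five-membered non-aromatic rings again stands apart from ethyl in this assay, now with an oxygen-bearing group: the change gives a number 19 percentage points higher from compound 3 to compound 4 (beyond the scatter) for this pair. Replacing the carbon-only two-ring group with the oxygen-bearing one gives a number 7 percentage points lower from compound 2 to compound 4 (within the scatter), so at this position in this assay the higher read-out does not depend on the rings being carbon only. Nothing measured on these compounds accounts for either step.

On these data alone, whether the rise needs two rings or only a group larger than ethyl stays open, and a single cyclohexyl ring on the same carbon would test this. Also open, as far as these compounds go, is whether a ring amine in place of the ring oxygen would keep the read-out.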